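This account rests on a few compounds, and the source may have more. Where it says the series, first, only, none or still open, it means among the compounds named here.

Measured compounds:
- Compound 1 `Cc1ccc(NC(=S)NC(=O)c2ccc(OCc3ccc(C(F)(F)F)cc3)cc2)cc1-c1nc2ccccc2[nH]1`: 6500 nM
- Compound 2 `Cc1ccc(NC(=O)NC(=O)c2ccc(OCc3ccccc3F)cc2)cc1-c1nc2ccccc2[nH]1`: 2520 nM
- Compound 3 `O=C(NC(=O)c1ccc(OCc2ccccc2F)cc1)Nc1ccc(Cl)c(-c2nc3ccccc3[nH]2)c1`: 120 nM

All three were tested in a functional assay on MGC-803 cells (Homo sapiens) for inhibition, read by MTT assay, with a stated time of 48 h; on this read-out higher numbers stand for weaker inhibition and lower numbers for stronger inhibition. Compound 3 gives the lowest number of the three; the nearest is compound 2, with a 21-fold lower number from compound 2 to compound 3 (1.32 log units; beyond the scatter) separating them, and compound 1 lies further still. Compound 4 `O=C(NC(=O)c1ccc(OCc2ccc(F)cc2)cc1)Nc1ccc(Cl)c(-c2nc3ccccc3[nH]2)c1` has not yet been measured. It differs from compound 3 only in 4-fluorophenyl in place of 2-fluorophenyl on a saturated chain carbon bound to an oxygen on an aromatic ring. Going by the values given here, no measured step bears on this change: the one step with a known size, from compound 2 to compound 3, concerns the chloro group on the other ring, and compounds 1 and 2 differ in more than one place. With no guide from the data, compound 4 is expected to stay close to compound 3, so a step of a 1.3-fold higher number from compound 3 to compound 4 (0.10 log units; within the scatter) is estimated, within the scatter. Compound 4 is therefore expected to give about 150 nM, likely between 50 nM and 500 nM.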

Compound 4, half-maximal inhibitory concentration: 61 nM
Compound 4: the middle estimate sits 2.5-fold (0.39 log units) above what was measured; low and high end bracket the measured number.
By their numbers in this assay, from the lowest: compounds 4 and 3 (each within the scatter of the next); then compound 2; then compound 1.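

Moving the fluorine, from 2-fluorophenyl to 4-fluorophenyl on the saturated chain carbon, is the first change at this end of the molecule that can be read on its own. In this assay it gives a 2.0-fold lower number from compound 3 to compound 4 (0.29 log units; within the scatter), so at this position the two fluorophenyl groups cannot be told apart. No measurement shown offers a reason for this result. Still open, as far as these compounds go, is how a plain phenyl, a 4-methoxyphenyl or a pyridine ring would read at this place, and whether a longer chain to the oxygen would change the number.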